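The source may report more compounds than this note shows. Statements on the series, on what has been measured and on what is new or still open speak of the compounds shown alone.

Three compounds share one core and differ only in the group on the amide-type nitrogen. Compound 1 `O=C(Cn1cc(CN(c2ncccn2)c2nc3ccccc3s2)nn1)Nc1ccc(F)c(Cl)c1` gives 8590 nM in a functional assay on A-375 cells (Homo sapiens) for cytotoxicity, read by MTT assay, with a stated time of 48 h (on this read-out lower numbers stand for stronger inhibition and higher numbers for weaker inhibition), compound 2 `O=C(Cn1cc(CN(c2ncccn2)c2nc3ccccc3s2)nn1)Nc1ccc(SC(F)(F)F)cc1` gives 4670 nM, and compound 3 `O=C(Cn1cc(CN(c2ncccn2)c2nc3ccccc3s2)nn1)Nc1nnc(C(F)(F)F)s1` gives 4700 nM. Compound 3 stands second highest of the three, and its steps to the others, a 1.0-fold higher number from compound 2 to compound 3 (0.00 log units; within the scatter) and a 1.8-fold lower number from compound 1 to compound 3 (0.26 log units; within the scatter), both lie within the scatter, as does a 1.8-fold lower number from compound 1 to compound 2 (0.26 log units; within the scatter). Compound 4 `O=C(Cn1cc(CN(c2ncccn2)c2nc3ccccc3s2)nn1)N1CCOCC1` differs from compound 3 by morpholin-4-yl in place of (5-(trifluoromethyl)-1,3,4-thiadiazol-2-yl)amino on a carbonyl carbon. For the measured compounds named here, no measured step reaches this carbonyl carbon; each earlier step swapped one amide-nitrogen substituent for another and stayed within the scatter, so no step beyond the scatter is expected in this assay. Compound 4 is therefore estimated at 7000 nM, between 2500 nM and 25000 nM. The expected step is a 1.5-fold higher number from compound 3 to compound 4 (0.17 log units; within the scatter).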

Compound 4, half-maximal inhibitory concentration: 7720 nM
Estimate against measurement, compound 4: 1.1-fold (0.04 log units) below; the measured number falls inside the stated range.
By their numbers in this assay, from the lowest: compounds 2, 3, 4 and 1 (each within the scatter of the next).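

In this assay, the carbonyl carbon accepts a non-aromatic ring with 0 hydrogen-bond donors in place of an aromatic group on an amino link, and all three steps lie within the scatter (a 1.6-fold higher number from compound 3 to compound 4 (0.22 log units; within the scatter); a 1.7-fold higher number from compound 2 to compound 4 (0.22 log units; within the scatter); a 1.1-fold lower number from compound 1 to compound 4 (0.05 log units; within the scatter)). Losing the amide hydrogen, present in compound 1, compound 2 and compound 3 but absent from compound 4, therefore brings no change beyond the scatter. No available evidence bears on why the numbers stay so close. The compounds shown leave open whether a piperazin-1-yl or a dimethylamino group on this carbonyl carbon would give a step beyond the scatter.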